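This account rests on a few compounds, and the source may have more. Where it says the series, first, only, none or still open, it means among the compounds named here.

Working notes on the series, all sharing one core. In a functional assay on HeLa cells (Homo sapiens) for inhibition, read by CCK-8 assay, with a stated time of 48 h (a higher number here means a weaker inhibitor, a lower number a stronger inhibitor), compound 1 (`COc1cc(-c2ccnc3cc(-c4ccc(C(F)(F)F)cc4)nn23)cc(OC)c1OC`) reads 1840 nM and compound 2 (`COc1cc(-c2ccnc3cc(-c4ccc5ccn(C)c5c4)nn23)cc(OC)c1OC`) reads 187 nM which makes compound 2 the lower of the two numbers and the stronger inhibitor so far. Within the data shown here, the one measured step (a 9.8-fold lower number from compound 1 to compound 2 (0.99 log units; beyond the scatter)) puts 1-methyl-1H-indol-6-yl in place of 4-(trifluoromethyl)phenyl on an aromatic carbon and lies beyond the scatter.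

Compound 3 (`COc1cc(-c2ccnc3cc(-c4ccc5cnn(C)c5c4)nn23)cc(OC)c1OC`) is still unmeasured and differs from compound 2 in one place (1-methyl-1H-indazol-6-yl in place of 1-methyl-1H-indol-6-yl on an aromatic carbon) with 1-methyl-1H-indazol-6-yl in place of 1-methyl-1H-indol-6-yl on the same aromatic carbon. Among the measured compounds shown here, the measured step bears on this only loosely: it exchanges a different group, and no measured step covers a change of this kind. For the measured compounds named here, with compound 2 at 187 nM as the only close neighbour, no change beyond the scatter is expected in this assay for compound 3. The expected step is a 1.3-fold higher number from compound 2 to compound 3 (0.13 log units; within the scatter) and would stay within the scatter. For compound 3 the estimate is 250 nM with an expected range of 90 nM to 700 nM in these notes.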

Compound 3, half-maximal inhibitory concentration: 97 nM
Compound 3: the middle estimate sits 2.6-fold (0.41 log units) above what was measured; the range from low to high includes it.
By their numbers in this assay, from the lowest: compounds 3 and 2 (each within the scatter of the next); then compound 1.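

At this aromatic carbon, the step from 1-methyl-1H-indol-6-yl to 1-methyl-1H-indazol-6-yl in this assay gives a 1.9-fold lower number from compound 2 to compound 3 (0.29 log units; within the scatter), so the second nitrogen in the five-membered ring and the extra hydrogen-bond acceptor counted for the entering group leave the two compounds level within the scatter. The other new step, a 19-fold lower number from compound 1 to compound 3 (1.28 log units; beyond the scatter), lies beyond the scatter and sits alongside a 9.8-fold lower number from compound 1 to compound 2 (0.99 log units; beyond the scatter), so among these three compounds both methylated two-ring groups give lower numbers than 4-(trifluoromethyl)phenyl, and neither step goes against that. No measured evidence on the compounds accounts for these differences.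

The compounds shown leave open whether the two-ring groups need the methyl on the ring nitrogen, since a hydrogen or a longer chain such as ethyl or propyl in that place has no reading here. They also leave open how a substituted phenyl carrying an amine or a carboxylic acid would compare with 4-(trifluoromethyl)phenyl at this carbon, and whether the methoxy groups of the shared core can be exchanged for a hydroxyl.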